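This account rests on a few compounds, and the source may have more. Where it says the series, first, only, none or still open, it means among the compounds named here.

Compound 1 `CCn1cc(C(=O)Nc2ccccc2)c(=O)c2cc(F)c(N3CCNC(C)C3)c(F)c21`: 12700 nM
Compound 2 `CCn1cc(C(=O)Nc2ccccc2O)c(=O)c2cc(F)c(N3CCNC(C)C3)c(F)c21`: 5370 nM
Compound 3 `CCn1cc(C(=O)Nc2ccc(C)c([N+](=O)[O-])c2)c(=O)c2cc(F)c(N3CCNC(C)C3)c(F)c21`: 11800 nM

These three amides share one core and were tested in a functional assay on HCT-116 cells (Homo sapiens) for cytotoxicity, read by MTT assay; a higher number here means a weaker inhibitor, a lower number a stronger inhibitor. Compound 2 has the lowest number of the three, set apart by a 2.4-fold lower number from compound 1 to compound 2 (0.37 log units; beyond the scatter) and by a 2.2-fold higher number from compound 2 to compound 3 (0.34 log units; beyond the scatter). The remaining pair shows no real separation, with a 1.1-fold lower number from compound 1 to compound 3 (0.03 log units; within the scatter).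

Compound 4 `CCn1cc(C(=O)Nc2ccc(OC)cc2)c(=O)c2cc(F)c(N3CCNC(C)C3)c(F)c21` has not yet been measured. Its difference is 4-methoxyphenyl in place of 2-hydroxyphenyl on an amide-type nitrogen. Going by the values given here, no measured compound carries a methoxy group, so the evidence is indirect. Compound 2 alone has the hydroxy group, and adding it gave the modest 2.4-fold lower number from compound 1 to compound 2 (0.37 log units; beyond the scatter). Among the compounds with values here, exchanging the 2-hydroxyphenyl of compound 2 for another substituted phenyl gave a 2.2-fold higher number from compound 2 to compound 3 (0.34 log units; beyond the scatter), the closest precedent. A similar modest rise is therefore expected in this assay, with the number returning towards the other two compounds. The expected change is a 2.0-fold higher number from compound 2 to compound 4 (0.31 log units; beyond the scatter). Compound 4 is estimated at 11000 nM, with an expected range of 5000 nM to 22000 nM.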

Compound 4, half-maximal inhibitory concentration: 3800 nM
Beside the measured number, compound 4's estimate is 2.9-fold (0.46 log units) above it; the whole stated range lies above it.
By their numbers in this assay, from the lowest: compounds 4 and 2 (each within the scatter of the next); then compounds 3 and 1 (each within the scatter of the next).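

In this assay, the amide-type nitrogen accepts 4-methoxyphenyl in place of 2-hydroxyphenyl with no real separation (a 1.4-fold lower number from compound 2 to compound 4 (0.15 log units; within the scatter)), even though the entering group has no hydrogen-bond donor, so the hydroxy group of compound 2 is not required for a number of this size. Adding a methoxy group to the phenyl gives a 3.3-fold lower number from compound 1 to compound 4 (0.52 log units; beyond the scatter) and 4-methoxyphenyl in place of 4-methyl-3-nitrophenyl gives a 3.1-fold lower number from compound 3 to compound 4 (0.49 log units; beyond the scatter), so a substituent on the phenyl does not by itself set the number, as compound 3 stays within the scatter of compound 1. No measurement shown accounts for these steps.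

The compounds shown leave open whether 2-methoxyphenyl or 4-hydroxyphenyl would behave alike, which would separate the oxygen group from its place on the ring. On these data alone, how an amine, a carboxylic acid or a longer ethoxy chain on the phenyl would fare also remains open.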